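Replacing acetamido on the saturated ring of compound 3

The compounds below may be only part of what the source reports. "The series", "measured", "known", "first", "only" and "open" are said of these compounds alone.

All three values in an ADME assay on cells (Hepatocyte, Mus musculus) for metabolic stability (a higher number here means that the compound lasts longer, a lower number that the compound disappears faster), are limits:
- compound 1 `O=c1cc(N2CCN(CC3CCC(NS(=O)(=O)c4ccccc4)CC3)CC2)sc2c([N+](=O)[O-])cc(C(F)(F)F)cc12` gives > 1.55 h
- compound 2 `O=C(NC1CCC(CN2CCN(c3cc(=O)c4cc(C(F)(F)F)cc([N+](=O)[O-])c4s3)CC2)CC1)c1ccccc1` gives > 1.55 h
- compound 3 `CC(=O)NC1CCC(CN2CCN(c3cc(=O)c4cc(C(F)(F)F)cc([N+](=O)[O-])c4s3)CC2)CC1` gives > 1.55 h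

Compound 3 gives > 1.55 h in this assay as a limit and not a number. The series offers only the limit of > 1.55 h in this assay, at which 3 of the 3 values shown sit, and no measured half-life.

Compound 4 `COc1ccc(C(=O)OC2CCC(CN3CCN(c4cc(=O)c5cc(C(F)(F)F)cc([N+](=O)[O-])c5s4)CC3)CC2)cc1` carries ((4-methoxyphenyl)carbonyl)oxy in place of acetamido on a saturated ring carbon. For the measured compounds named here, the steps that bear on this are a step that the two limits leave unreadable from compound 1 to compound 2 and a step that the two limits leave unreadable from compound 1 to compound 3 and a step that the two limits leave unreadable from compound 2 to compound 3, and none has a readable size. On these data alone, none of them removes the nitrogen that leaves here, so the direction stays open, with a modest loss allowed for. The expected change is an at least 1.1-fold lower number from compound 3 to compound 4 (0.07 log units; that floor lies within the scatter), an uncertain estimate. Compound 4 is estimated at 1.3 h (expected range 0.4 h to 3.5 h).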

Compound 4, half-life: 0.295 h
Beside the measured number, compound 4's estimate is 4.4-fold (0.64 log units) above it; the whole stated range lies above it.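

In this assay, this saturated ring carbon now shows a readable change, with an at least 5.2-fold lower number from compound 3 to compound 4 (0.72 log units; beyond the scatter), an at least 5.2-fold lower number from compound 2 to compound 4 (0.72 log units; beyond the scatter) and an at least 5.2-fold lower number from compound 1 to compound 4 (0.72 log units; beyond the scatter). The steps among compound 1, compound 2 and compound 3 cannot be read, and compound 4, whose group carries no nitrogen, is the only compound with a measured half-life, the others resting on one limit: the limit of > 1.55 h in this assay, at which 3 of the 4 values shown sit.

The change replaces the nitrogen link with an oxygen link and brings in a 4-methoxyphenyl ring at once, and the compounds shown do not separate the two. On these data alone, how a 4-methoxybenzamido or an acetoxy group would fare at this carbon stays open.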